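Swapping a nitro group for diethylamino and hydroxyl

A few compounds are considered here, and "the series" means these few. Any claim that something is new, unique, unknown or untested is made for them only; others in the source may bear on it.

From the compounds shown here alone, compound 1 `O=C(N/N=C/c1ccc([N+](=O)[O-])cc1)Nc1cc2c(Nc3ccc(F)c(Cl)c3)ncnc2cc1O[C@H]1CCOC1` was recorded in a functional assay on MCF7 cells (Homo sapiens) for cytotoxicity, read by MTT assay, with a stated time of 72 h (on this read-out higher numbers stand for weaker inhibition and lower numbers for stronger inhibition), as "not active" (no number reported), with no number attached, so its standing on this scale is unknown. Compound 2 `O=C(N/N=C/c1ccc(O)cc1O)Nc1cc2c(Nc3ccc(F)c(Cl)c3)ncnc2cc1O[C@H]1CCOC1` carries two hydroxyl groups on the same ring and gives 5350 nM in this assay. Compound 3 `CCN(CC)c1ccc(/C=N/NC(=O)Nc2cc3c(Nc4ccc(F)c(Cl)c4)ncnc3cc2O[C@H]2CCOC2)c(O)c1` differs from compound 1 by 4-(diethylamino)-2-hydroxyphenyl in place of 4-nitrophenyl on a carbon with a double bond to nitrogen. Within the data shown here, with no measured step between paired compounds, a move from an inactive report toward measurable, modest inhibition is expected in this assay, though the size is uncertain. Compound 3 is estimated at 5000 nM, within a range of 1500 nM to 20000 nM.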

Compound 3, half-maximal inhibitory concentration: 15600 nM
Compound 3: middle estimate off by 3.1-fold (0.49 log units), on the low side, within the range that was stated.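

In this assay, diethylamino in place of hydroxy on an aromatic carbon gives a 2.9-fold higher number from compound 2 to compound 3 (0.46 log units; beyond the scatter) and so modestly weakens inhibition, the first size this data set puts on a change at this place. Compound 3 also shows that 4-(diethylamino)-2-hydroxyphenyl keeps a measurable number, but compound 1 has none, so the step from 4-nitrophenyl cannot be read. No measurement shown accounts for the weakening. From the compounds shown here alone, whether a smaller dimethylamino group or a carboxylic acid on that aromatic carbon would bring the number closer to that of compound 2 remains open.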